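Three Analogues at the Assay Limit, One Yet Unmeasured

The compounds below may be only part of what the source reports. "The series", "measured", "known", "first", "only" and "open" are said of these compounds alone.

Compound 1 `N#Cc1cnc(NCc2cnccc2C(F)(F)F)cc1N[C@H]1C[C@@H](O)C1`: > 10000 nM
Compound 2 `N#Cc1cnc(NCc2cnccc2C(F)(F)F)cc1N[C@H]1C[C@H](O)C1`: > 10000 nM
Compound 3 `CO[C@H]1CC[C@H](CNc2cc(NCc3cnccc3C(F)(F)F)ncc2C#N)CC1`: > 10000 nM

In an assay on isolated protein for inhibition of protein kinase C delta type (Homo sapiens), read by TR-FRET, with a stated time of 2 h (on this read-out higher numbers stand for weaker inhibition and lower numbers for stronger inhibition), compound 1 gives only a limit, > 10000 nM. Compound 2 likewise sits at a limit, > 10000 nM, and compound 3 gives a limit, > 10000 nM. All three values rest on (the limit of > 10000 nM in this assay, at which 3 of the 3 values shown sit), so the steps a step that the two limits leave unreadable from compound 1 to compound 2, a step that the two limits leave unreadable from compound 1 to compound 3 and a step that the two limits leave unreadable from compound 2 to compound 3 cannot be read, even though the fact that compounds 1 and 2 differ only in the configuration as drawn describes mirror images.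

Compound 4 `N#Cc1cnc(NCc2cnccc2C(F)(F)F)cc1N[C@H]1CC[C@@H](C(N)=O)CC1` carries 4-carbamoylcyclohexyl in place of 3-hydroxycyclobutyl on a nitrogen on an aromatic ring. For the measured compounds named here, the step from compound 1 to compound 3 also exchanged the 3-hydroxycyclobutyl group and stayed unreadable at the limit, so no measured step points in either direction. Compound 4 is therefore expected to remain weak, with an estimated 20000 nM spanning 3000 nM to 100000 nM, and the expected step that the limit leaves unreadable from compound 1 to compound 4 is judged as within the scatter.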

Compound 4, half-maximal inhibitory concentration: 400 nM
Estimate against measurement, compound 4: 50-fold (1.70 log units) above; measured number outside the range, below it.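

For the compounds shown here, at this place, on a nitrogen on an aromatic ring, 4-carbamoylcyclohexyl produces the first readable change in this assay: an at least 25-fold lower number from compound 1 to compound 4 (1.39 log units; beyond the scatter), and an at least 25-fold lower number from compound 2 to compound 4 (1.39 log units; beyond the scatter). The same group in place of (4-methoxycyclohexyl)methyl gives an at least 25-fold lower number from compound 3 to compound 4 (1.39 log units; beyond the scatter), so a six-membered ring of carbon only does not by itself bring this gain. These steps are bounds, not exact sizes, because each starts from a limit: the limit of > 10000 nM in this assay, at which 3 of the 4 values shown sit.

From the compounds shown here alone, how much of the gain belongs to the carbamoyl group itself remains open. A carboxylic acid or an amine on the same cyclohexyl ring would bear on that question.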